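Working notes: methoxy in place of bromo

The compounds below may be only part of what the source reports. "The series", "measured", "known", "first", "only" and "open" are said of these compounds alone.

compound 1 `CC(C)(C)Nc1nc(Nc2ccc(C3(C)NC(=O)c4ccccc4N3)cc2)nc(NC(C)(C)C)n1`: 159000 nM
compound 2 `CC1(c2ccc(NC(c3ccc(Br)cc3)c3nnnn3C(C)(C)C)cc2)NC(=O)c2ccccc2N1`: > 400000 nM
compound 3 `CC1(c2ccc(NC(c3ccc(Br)cc3)c3nnnn3C3CCCCC3)cc2)NC(=O)c2ccccc2N1`: > 400000 nM

All three readings come from an ADME assay on Vero cells (Chlorocebus sabaeus) for cytotoxicity, read by MTT assay, with a stated time of 72 h; on this read-out lower numbers stand for higher toxicity in this test and higher numbers for lower toxicity in this test. Compound 1 is the only one of the three with a number, 159000 nM. Compound 2 stands at a limit of the assay, > 400000 nM, so no number is known for it. Compound 3 is also at a limit, > 400000 nM. Two of the three compounds therefore rest on (the limit of > 400000 nM in this assay, at which 2 of the 3 values shown sit).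

Compound 4 `COc1ccc(C(Nc2ccc(C3(C)NC(=O)c4ccccc4N3)cc2)c2nnnn2C(C)(C)C)cc1` is still to be measured. Its difference from compound 2 is methoxy in place of bromo on an aromatic carbon, which is methoxy in place of bromo on an aromatic carbon, para to a large group. Among the measured compounds shown here, the only measured step is a step that the two limits leave unreadable from compound 2 to compound 3. That step is cyclohexyl in place of tert-butyl on an aromatic nitrogen, so it does not touch the bromo and gives no size to carry over.

The expectation rests on the standing of compound 2 alone: no step beyond the scatter is expected in this assay, and a report as a limit is the likeliest outcome. The expected step is a number no higher from compound 2 to compound 4 (the limit leaves the size open). For compound 4 the estimated value is 400000 nM, with an expected range of 180000 nM to 800000 nM.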

Compound 4, half-maximal cytotoxic concentration: > 400000 nM
Compound 4: a limit, no number; the forecaster's own chance of this, stated with the estimate: 65%; the middle value lies on the limit itself.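

Compound 2 and compound 4 are both reported only as limits in this assay, so the change from 4-bromophenyl to 4-methoxyphenyl gives no readable step: the limit of > 400000 nM in this assay, at which 3 of the 4 values shown sit.

The compounds shown leave open what the half-maximal cytotoxic concentrations of compound 2 and compound 4 actually are, and whether methoxy in place of bromo alters them at all.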